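The source may report more compounds than this note shows. Statements on the series, on what has been measured and on what is new or still open speak of the compounds shown alone.

Working notes on the series. Going by the values given here, compound 1 `CNC(=O)c1cc(Oc2ccc(C3=NNC(c4cccc(Br)c4)C3)cc2)ccn1` is the only member with a number in a functional assay on MCF7 cells (Homo sapiens) for cytotoxicity, read by MTT assay, with a stated time of 72 h; on this read-out higher numbers stand for weaker inhibition and lower numbers for stronger inhibition: in this assay compound 1 gives 1960 nM. Compound 2 `CNC(=O)c1cc(Oc2ccc(C3=NNC(c4ccc(C#N)cc4)C3)cc2)ccn1` gives "not determined" (no result reported) in this assay, and compound 3 `CNC(=O)c1cc(Oc2ccc(C3=NNC(c4ccc(F)cc4Cl)C3)cc2)ccn1` gives "not determined" (no result reported) in this assay: no result was reported for either, so nothing can be said of their standing. Compound 4 `CNC(=O)c1cc(Oc2ccc(C3=NNC(c4cccc([N+](=O)[O-])c4)C3)cc2)ccn1` carries the shared core of compound 1 and differs from it only as counted here: nitro in place of bromo on an aromatic carbon. Among the compounds with values here, no pair of measured compounds shows this change, so the size of the step is unknown; the expectation is a step of modest size, toward weaker inhibition if any, and possibly none beyond the scatter, which for compound 4 reads a 1.3-fold higher number from compound 1 to compound 4 (0.11 log units; within the scatter). Compound 4 is thus estimated at 2500 nM, with a range from 800 nM to 8000 nM.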

Compound 4, half-maximal inhibitory concentration: 35400 nM
Estimate against measurement, compound 4: 14-fold (1.15 log units) below; measured number outside the range, above it.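

On this aromatic carbon the group is not interchangeable: in this assay the change from 3-bromophenyl to 3-nitrophenyl gives an 18-fold higher number from compound 1 to compound 4 (1.26 log units; beyond the scatter) and so moves toward weaker inhibition. Going by these compounds alone, this is the first sign that the series responds strongly to what this position carries. No measurement at hand bears on the cause of this step.

With numbers for only these two groups, no trend across substituents can be drawn here, and compound 2 and compound 3 add nothing without a result. On these data alone, how an amine or a carboxylic acid on this same carbon would read remains open.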